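Methoxy to Methyl on the Carbonyl of an Aryltriazene

The compounds below may be only part of what the source reports. "The series", "measured", "known", "first", "only" and "open" are said of these compounds alone.

Within the data shown here, compound 1, `COC(=O)c1cccc(/N=N/N(C)C)c1`, is one of two compounds measured in a functional assay on L1210 cells (Mus musculus) for antiproliferative activity; a lower number here means a less potent compound, a higher number a more potent compound, by a factor of ten per unit of this negative logarithm. In this assay compound 1 gives 3.42, and compound 2, `CN(C)/N=N/c1c(Cl)cc(Cl)cc1C(N)=O`, gives 3.14, the two numbers lying within the usual scatter of each other. Compound 3, `CC(=O)c1cccc(/N=N/N(C)C)c1`, differs from compound 1 by methyl in place of methoxy on a carbonyl carbon. Among the measured compounds shown here, no step between measured compounds is available to gauge this change, so compound 3 is expected to stay close to compound 1, the estimated step of a number 0.02 log units lower from compound 1 to compound 3 (within the scatter) being no larger than the scatter. Compound 3 is estimated at 3.4, between 2.9 and 3.9.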

Compound 3, logarithm of the reciprocal of the active concentration, log(1/C): 3.58
For compound 3 the middle estimate is 0.18 log units below the measured one; the range from low to high includes it.
By their numbers in this assay, from the lowest: compounds 2, 1 and 3 (each within the scatter of the next, the first and the last beyond it).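

In this assay, methyl in place of methoxy on a carbonyl carbon gives the first step read at this position: a number 0.16 log units higher from compound 1 to compound 3 (within the scatter). Methoxycarbonyl and acetyl are thus not told apart here, and the position accepts the smaller methyl without a change beyond the scatter. Nothing available bears on why the two groups read alike.

From the compounds shown here alone, whether a longer chain such as propyl on this carbonyl carbon would stay as close to compound 1 remains open. So does the outcome for a carboxylic acid in place of the methoxycarbonyl group.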